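The compounds below may be only part of what the source reports. "The series", "measured", "known", "first", "only" and "open" are said of these compounds alone.

Compound 3 `Cc1nc(Nc2cccc(Cl)c2)sc1C(=O)/C=C/c1ccccc1` stands in a functional assay on PC-3 cells (Homo sapiens) for cytotoxicity, read by MTT assay (a higher number here means a weaker inhibitor, a lower number a stronger inhibitor), only at a limit: compound 3 gives > 25000 nM. Compound 1 `COc1ccc(/C=C/C(=O)c2sc(Nc3ccc(Cl)cc3)nc2C)cc1` likewise returns only a limit in this assay, > 25000 nM. Compound 2 `Cc1nc(Nc2ccc(Cl)cc2)sc1C(=O)/C=C/c1ccccc1` gives a number in this assay, 24600 nM. The two measured steps, an at least 1.0-fold lower number from compound 1 to compound 2 (0.00 log units; that floor lies within the scatter) and an at least 1.0-fold higher number from compound 2 to compound 3 (0.00 log units; that floor lies within the scatter), are both floors lying within the scatter, so neither the loss of the methoxy nor the shift of the chloro on the anilino ring is resolved; this follows from the limit of > 25000 nM in this assay, at which 2 of the 3 values shown sit. Compound 4 `Cc1nc(Nc2ccc(Cl)c(Cl)c2)sc1C(=O)/C=C/c1ccccc1` differs from compound 3 by chloro in place of hydrogen on an aromatic carbon. For the measured compounds named here, no measured step touches the addition of a second chloro; what the series shows is that three variations of the aryl groups on the shared core all sit at or close to the limit. The expected step is therefore a number no higher from compound 3 to compound 4 (the limit leaves the size open), nothing beyond the scatter. Compound 4 is estimated at 25000 nM, between 8000 nM and 60000 nM, with a substantial chance that this assay again reports only a limit.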

Compound 4, half-maximal inhibitory concentration: 7990 nM
The estimate for compound 4 lay 3.1-fold (0.50 log units) above the measured number; measured number outside the range, below it.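

Chloro in place of hydrogen on the anilino ring is the first change in the series to resolve in this assay: a 3.1-fold lower number from compound 2 to compound 4 (0.49 log units; beyond the scatter). Seen from the other monochloro compound, the change gives an at least 3.1-fold lower number from compound 3 to compound 4 (0.49 log units; beyond the scatter), and that size is only a floor, with compound 3 standing at a limit: the limit of > 25000 nM in this assay, at which 2 of the 4 values shown sit. The 3,4-dichlorophenyl group therefore separates from both monochloro rings, whereas neither the loss of the methoxy nor the shift of the single chloro could be read, though the resolved step is only modest.

Still open, going by these compounds, is whether the gain needs a second chloro or would also appear with a bromo, trifluoromethyl or nitrile group in the same place. Also open, on these data alone, is whether a methoxy or an amine on the other aromatic ring would have a readable effect alongside the 3,4-dichlorophenyl group.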